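Swapping Methyl for Ethoxycarbonyl on a Ring Nitrogen

A few compounds are considered here, and "the series" means these few. Any claim that something is new, unique, unknown or untested is made for them only; others in the source may bear on it.

Compound 1 `CCOC(=O)N1CCN(CCC(=O)O[C@@H]2C[C@@H]3CC[C@@]2(C)C3(C)C)CC1` gives 150000 nM in an ADME assay on MDCK cells (Canis lupus familiaris) for cytotoxicity, read by MTT assay, with a stated time of 48 h; a lower number here means that less compound is tolerated, a higher number that more compound is tolerated.
Compound 2 `CN1CCN(CCC(=O)O[C@@H]2C[C@@H]3CC[C@@]2(C)C3(C)C)CC1` gives 48100 nM.
Compound 3 `CN1CCN(CC(=O)O[C@@H]2C[C@@H]3CC[C@@]2(C)C3(C)C)CC1` gives 103000 nM.

Compound 4 `CCOC(=O)N1CCN(CC(=O)O[C@@H]2C[C@@H]3CC[C@@]2(C)C3(C)C)CC1` has not yet been measured. Compounds 1 and 2 share one core and differ in a single place: ethoxycarbonyl in place of methyl on an amine nitrogen in a ring. That change gave a 3.1-fold higher number from compound 2 to compound 1 (0.49 log units; beyond the scatter), so compound 1 is tolerated at a higher concentration than compound 2. Compound 3 and compound 4 form a second pair on a different core; how that core differs from the core of compound 2 is not broken down here. Within this second pair the change is the same one: ethoxycarbonyl in place of methyl on an amine nitrogen in a ring. Compound 3 and compound 1 lie within the usual scatter of each other. Because the earlier step of a 3.1-fold higher number from compound 2 to compound 1 (0.49 log units; beyond the scatter) went beyond the scatter, a step of similar size is expected here, though this rests on a single prior pair. The step from compound 3 to compound 4 is estimated as a 2.4-fold higher number from compound 3 to compound 4 (0.39 log units; beyond the scatter). Compound 4 is therefore expected near 250000 nM, likely between 130000 nM and 500000 nM.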

Compound 4, half-maximal cytotoxic concentration: > 852000 nM
Compound 4: only a limit was reported; the forecaster's own chance of this, stated with the estimate: 30%; at least 3.4-fold (0.53 log units) between middle value and limit.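

In this assay the second core gave an at least 8.2-fold higher number from compound 3 to compound 4 (0.91 log units; beyond the scatter) when ethoxycarbonyl took the place of methyl on an amine nitrogen in a ring, so the direction seen on the first core carried over to this pair. As far as these compounds go, for compound 4 the reported > 852000 nM is a limit of the assay and not a number, so the full size of this step stays unknown. The two pairs agree in direction, but they cannot show whether the size of the change carries over from one core to the other: the same change on two cores in this assay, a 3.1-fold higher number (0.49 log units; beyond the scatter) from compound 2 to compound 1 and an at least 8.2-fold higher number (0.91 log units; beyond the scatter) from compound 3 to compound 4; the limit leaves it open whether they differ.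

The compounds shown leave open whether other groups on that ring nitrogen, such as an acetyl group, a benzyl group or a plain hydrogen, would shift the number the same way as ethoxycarbonyl. They also leave open whether the same change would still raise the tolerated concentration on a core with a longer chain, since two pairs are a narrow basis for a rule.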